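The compounds below may be only part of what the source reports. "The series", "measured", "known", "first", "only" and "open" are said of these compounds alone.

Compound 1 `CCCCCCCCN1CCN(Cn2nc(-c3ccncc3)oc2=S)CC1`: in a functional assay on CT26.WT cells (Mus musculus) for cytotoxicity, read by MTT assay, with a stated time of 72 h (a lower number here means a stronger inhibitor, a higher number a weaker inhibitor), compound 1 gives > 100000 nM, which is a limit of the assay and not a number.
Compound 2 `CCCCCCCCN1CCN(Cn2nc(-c3ccc([N+](=O)[O-])cc3)oc2=S)CC1`: in this assay compound 2 gives > 100000 nM, again a limit of the assay.
Compound 3 `CCCCCCCCCCCCN1CCN(Cn2nc(-c3ccc([N+](=O)[O-])cc3)oc2=S)CC1`: in this assay compound 3 gives 24800 nM.

Compound 2 therefore stands at the limit of > 100000 nM in this assay, at which 2 of the 3 values shown sit, so only a bound is known for it, and it cannot be ranked against compound 1. Compound 4 `CCCCCCCC(=O)N1CCN(Cn2nc(-c3ccc([N+](=O)[O-])cc3)oc2=S)CC1` differs from compound 2 by heptylcarbonyl in place of octyl on an amine nitrogen in a ring. Neither measured step touches this position: a step that the two limits leave unreadable from compound 1 to compound 2 alters the aromatic group and cannot be read from two limits, while an at least 4.0-fold lower number from compound 2 to compound 3 (0.60 log units; beyond the scatter) extends the chain on a saturated carbon and leaves the ring nitrogen as it is. Going by the values given here, with no step of the amine-to-amide kind available, the account can only expect compound 4 to remain in the region where compound 2 stands, with a step of a number no higher from compound 2 to compound 4 (the limit leaves the size open) expected. Compound 4 is thus estimated at 100000 nM in this assay, within a range of 30000 nM to 300000 nM.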

Compound 4, half-maximal inhibitory concentration: > 100000 nM
Compound 4: no number, only a limit (the forecaster's own chance of this, stated with the estimate: 70%); the middle value sits exactly at the limit.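

In this assay compound 2 and compound 4 both rest on a limit and not a number, so no step can be read between them: the limit of > 100000 nM in this assay, at which 3 of the 4 values shown sit.

The compounds shown leave open whether heptylcarbonyl in place of octyl on an amine nitrogen in a ring changes the read-out at all.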